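Opening the Carbocycle: From Compound 2 to Compound 4

This account rests on a few compounds, and the source may have more. Where it says the series, first, only, none or still open, it means among the compounds named here.

Compound 1 `CCCn1c(=O)n(C2CCC(COC(C)=O)O2)c2nc(NC(C)=O)nc(O)c21`: 100%
Compound 2 `C=CCn1c(=O)n(C2CCC(CO)C2)c2nc(N)nc(O)c21`: 26%
Compound 3 `NCC(O)Cn1c(=O)n(C2OC(CO)[C@@H](O)[C@H]2O)c2nc(N)nc(O)c21`: 110%

In a functional assay on the whole organism (B cells) with Mus musculus as the target (on this read-out lower numbers stand for smaller maximal responses and higher numbers for larger maximal responses), compound 2 gives 26%, the lowest of the three numbers. Compound 1 gives 100%, higher by a gap beyond the scatter, and compound 3 gives 110%, higher by a still larger gap, also beyond the scatter. Compound 4 `C=CCn1c(=O)n(CCCCO)c2nc(N)nc(O)c21` differs from compound 2 in one place: a group of 5 heavy atoms (4 carbon, 1 oxygen; no ring) in place of a group of 7 heavy atoms (6 carbon, 1 oxygen; one five-membered non-aromatic ring of carbon only), on an aromatic nitrogen. Among the compounds with values here, no measured pair shows this change, so its effect is not known from the data; compound 1 and compound 3 carry no such carbocycle and give higher numbers, yet they differ from compound 2 elsewhere as well. Compound 4 is therefore expected to give 45%, in a range from 15% to 90%. The expected step is a number 19 percentage points higher from compound 2 to compound 4 (beyond the scatter), a moderate rise that may not clear the scatter.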

Compound 4, largest response reached (reported as maximal response), in percent of the reference or control that the assay uses: 12%
Compound 4: middle estimate off by 33 percentage points, on the high side; measured number outside the range, below it.
By their numbers in this assay, from the lowest: compound 4; then compound 2; then compounds 1 and 3 (each within the scatter of the next).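

In this assay, opening the carbocycle to the 4-hydroxybutyl chain on the aromatic nitrogen gives a number 14 percentage points lower from compound 2 to compound 4 (beyond the scatter). At this position, then, the five-membered ring is not needed for a low maximal response, and removing it does not by itself raise the number. The data offer no explanation for this direction of change. As far as these compounds go, it remains open how a longer chain, or an amine or a carboxylic acid in place of the hydroxyl, would read here. From the compounds shown here alone, whether the same change would lower the number with a group other than allyl on the shared core also remains open.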